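The source may hold more compounds than are shown below. What is called first, only, known or untested is meant among the compounds shown, and "the series" means these compounds.

In an ADME assay on Vero cells (Chlorocebus sabaeus) for cytotoxicity, read by polymerase chain reaction, with a stated time of 18 h (on this read-out lower numbers stand for higher toxicity in this test and higher numbers for lower toxicity in this test), compound 2 `O=c1cc(CSc2nc3ccccc3c(=O)[nH]2)c2ccc(OS(=O)(=O)c3ccc(F)cc3)cc2o1` gives 30000 nM, the lowest of the three numbers at hand. Compound 1 `O=c1cc(CSc2nc3ccccc3c(=O)[nH]2)c2ccc(OS(=O)(=O)c3ccccc3)cc2o1` gives 178000 nM and compound 3 `Cc1ccc2nc(SCc3cc(=O)oc4cc(OS(=O)(=O)c5ccc(F)cc5)ccc34)[nH]c(=O)c2c1` gives 86400 nM. From the compounds shown here alone, compound 4 `Cc1ccc(COc2ccc3c(CSc4nc5ccccc5c(=O)[nH]4)cc(=O)oc3c2)cc1` is untested; it differs from compound 2 by 4-methylbenzyl in place of (4-fluorophenyl)sulfonyl on an oxygen on an aromatic ring. Going by the values given here, no measured step swaps the whole group on that oxygen. The two nearest hints are a 5.9-fold lower number from compound 1 to compound 2 (0.77 log units; beyond the scatter) and a 2.9-fold higher number from compound 2 to compound 3 (0.46 log units; beyond the scatter), both modest changes from single substituents on the aromatic rings. Since the group that leaves carries the fluoro that went with the lower number of compound 2, the expectation is a modest rise in this assay, within a 2.0-fold higher number from compound 2 to compound 4 (0.30 log units; within the scatter), so compound 4 is expected near 60000 nM, from 15000 nM to 240000 nM.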

Compound 4, half-maximal cytotoxic concentration: 102000 nM
Beside the measured number, compound 4's estimate is 1.7-fold (0.23 log units) below it; low and high end bracket the measured number.
By their numbers in this assay, from the lowest: compound 2; then compounds 3, 4 and 1 (each within the scatter of the next, the first and the last beyond it).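

Swapping the whole group on this oxygen, not just a ring substituent, also shifts the number in this assay: the step is a 3.4-fold higher number from compound 2 to compound 4 (0.53 log units; beyond the scatter). The matching swap, 4-methylbenzyl in place of phenylsulfonyl, gives a 1.7-fold lower number from compound 1 to compound 4 (0.24 log units; within the scatter), so the same kind of swap reads differently depending on which sulfonyl group leaves. No measurement at hand gives a reason for these steps.

Still open, from the compounds shown here alone, is how a 4-fluorobenzyl group on this oxygen would read, which would separate the fluoro from the sulfonyl. An amine or a carboxylic acid at the end of a longer chain there is also untested in what is shown.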